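The source may report more compounds than this note shows. Statements on the series, on what has been measured and on what is new or still open speak of the compounds shown alone.

Compound 1 `O=C(c1ccc(Cl)cc1)N1CCC(NS(=O)(=O)c2cc(S(=O)(=O)c3ccccc3)ccc2C(F)(F)F)CC1` gives 3100 nM in a physicochemical assay for solubility (on this read-out higher numbers stand for higher solubility and lower numbers for lower solubility), the lower of the two numbers shown, while compound 2 `CN(C)c1ccc(C(=O)N2CCC(NS(=O)(=O)c3cc(S(=O)(=O)c4ccccc4)ccc3C(F)(F)F)CC2)cc1` gives 50000 nM. For the measured compounds named here, the only measured step, a 16-fold higher number from compound 1 to compound 2 (1.21 log units; beyond the scatter), alters a different position than the change leading to compound 3 `O=C(O)c1ccc(S(=O)(=O)N2CCC(NS(=O)(=O)c3cc(S(=O)(=O)c4ccccc4)ccc3C(F)(F)F)CC2)cc1`, which is (4-carboxyphenyl)sulfonyl in place of (4-chlorophenyl)carbonyl on an amine nitrogen in a ring. Going by the values given here, no measured step therefore bears directly on this change, though the step from compound 1 to compound 2 shows that a substitution in this part of the molecule can move the number far beyond the scatter. Compound 3 is expected to give 30000 nM, within 5000 nM to 150000 nM. The expected step is a 9.7-fold higher number from compound 1 to compound 3 (0.99 log units; beyond the scatter), upward.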

Compound 3, solubility: 12500 nM
Compound 3: middle estimate off by 2.4-fold (0.38 log units), on the high side; measured number inside the range.
By their numbers in this assay, from the lowest: compound 1; then compound 3; then compound 2.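

On the amine nitrogen in the ring, this assay gives a 4.0-fold higher number from compound 1 to compound 3 (0.61 log units; beyond the scatter) when (4-carboxyphenyl)sulfonyl replaces (4-chlorophenyl)carbonyl. Set against (4-(dimethylamino)phenyl)carbonyl, the same entering group gives a 4.0-fold lower number from compound 2 to compound 3 (0.60 log units; beyond the scatter) and so places compound 3 between the two earlier compounds, with both steps beyond the scatter. Nothing available explains these differences.

From the compounds shown here alone, the sulfonyl link and the carboxylic acid enter together, so their separate contributions remain open. A (4-carboxyphenyl)carbonyl group or a (4-chlorophenyl)sulfonyl group at this nitrogen would pull them apart.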